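The source may report more compounds than this note shows. Statements on the series, on what has been measured and on what is new or still open speak of the compounds shown alone.

Measured compounds in a functional assay on P388 cells (Mus musculus) for cytotoxicity, read by MTT assay, with a stated time of 72 h; on this read-out lower numbers stand for stronger inhibition and higher numbers for weaker inhibition: compound 1 `CCOc1cccc(/C=N/c2c(C)n(C)n(-c3ccccc3)c2=O)c1` gives 295000000 nM; compound 2 `COc1cccc(/C=N/c2c(C)n(C)n(-c3ccccc3)c2=O)c1` gives 105000000 nM; compound 3 `COc1cccc(/C=N/c2c(C)n(C)n(-c3ccccc3)c2=O)c1O` gives 851000000 nM.

Compound 2 stands lowest of the three numbers: the step of a 2.8-fold lower number from compound 1 to compound 2 (0.45 log units; beyond the scatter) and the step of an 8.1-fold higher number from compound 2 to compound 3 (0.91 log units; beyond the scatter) both leave it at the low end, each beyond the scatter.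

Compound 4 `Cc1c(/N=C/c2ccc(Cl)cc2Cl)c(=O)n(-c2ccccc2)n1C` differs from compound 2 by 2,4-dichlorophenyl in place of 3-methoxyphenyl on a carbon with a double bond to nitrogen. Among the measured compounds shown here, no measured step exchanges one whole aryl ring for another; the two known steps only alter substituents on the 3-methoxyphenyl ring and are of modest size, one in each direction. Nothing supports a large step in either direction, so the expected change in this assay from compound 2 to compound 4 is a 1.4-fold higher number from compound 2 to compound 4 (0.15 log units; within the scatter), with wide uncertainty. Compound 4 is therefore estimated at 150000000 nM (range 30000000 nM to 800000000 nM).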

Compound 4, half-maximal inhibitory concentration: 363000000 nM
Estimate against measurement, compound 4: 2.4-fold (0.38 log units) below; measured number inside the range.
By their numbers in this assay, from the lowest: compound 2; then compounds 1 and 4 (each within the scatter of the next); then compound 3.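

In this assay, among the compounds shown here, the first exchange of a whole aryl group on a carbon with a double bond to nitrogen gives a 3.5-fold higher number from compound 2 to compound 4 (0.54 log units; beyond the scatter), so this place responds to replacing the ring as well as to changing substituents on 3-methoxyphenyl. For the compounds shown here, the two groups have equal heavy-atom counts but differ in hydrogen-bond acceptors, and the single step cannot separate the contributions of the two chlorines or of losing the methoxy group. No available evidence explains the change. As far as these compounds go, whether an aryl group carrying an amine or a carboxylic acid at this place would give a lower number than compound 2 remains open.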